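A Third Ring Swap on a Shared Core

The source may report more compounds than this note shows. Statements on the series, on what has been measured and on what is new or still open speak of the compounds shown alone.

Compound 1 `COc1cc2ncnc(Nc3ccc(F)c(Cl)c3)c2cc1NC(=O)N/N=C/c1ccc(F)cc1Cl` and compound 2 `COc1ccc(/C=N/NC(=O)Nc2cc3c(Nc4ccc(F)c(Cl)c4)ncnc3cc2OC)cc1` share a core and differ only in one ring. Going by the values given here, in a functional assay on A549 cells (Homo sapiens) for cytotoxicity, read by MTT assay, with a stated time of 72 h (on this read-out lower numbers stand for stronger inhibition and higher numbers for weaker inhibition), compound 1 gives 28200 nM and compound 2 gives 28100 nM, so compound 2 stands level with its only neighbour. Compound 3 `COc1cc2ncnc(Nc3ccc(F)c(Cl)c3)c2cc1NC(=O)N/N=C/c1cc(Br)c(O)c(Br)c1` puts 3,5-dibromo-4-hydroxyphenyl in place of 4-methoxyphenyl on a carbon with a double bond to nitrogen. Among the compounds with values here, one measured step bears on this place, a 1.0-fold lower number from compound 1 to compound 2 (0.00 log units; within the scatter), and it lies within the scatter. Within the data shown here, that single swap moved nothing, but no measured compound carries bromine or a hydroxyl group, so the evidence is thin. No shift beyond the scatter is therefore expected in this assay, and the expected size is a 1.1-fold lower number from compound 2 to compound 3 (0.05 log units; within the scatter). For compound 3 the estimated value is 25000 nM, with an expected range from 8000 nM to 60000 nM.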

Compound 3, half-maximal inhibitory concentration: 34600 nM
Beside the measured number, compound 3's estimate is 1.4-fold (0.14 log units) below it, and the stated range covers the measured number.
By their numbers in this assay, from the lowest: compounds 2, 1 and 3 (each within the scatter of the next).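

In this assay the new ring gives a 1.2-fold higher number from compound 2 to compound 3 (0.09 log units; within the scatter), and measured against the ring of compound 1 it gives a 1.2-fold higher number from compound 1 to compound 3 (0.09 log units; within the scatter). Among these three compounds, then, the number stays level even when 3,5-dibromo-4-hydroxyphenyl, the first ring here with bromine and a hydroxyl group, sits on the carbon with a double bond to nitrogen, which extends the flat picture from the single earlier swap. Nothing available gives a reason for this flat result.

From the compounds shown here alone, all three compounds carry a six-membered aromatic ring of carbon only at this place, so it remains open what a ring bearing an amine or a carboxylic acid, or a plain alkyl chain with no ring, would do. Whether any such group would move the number beyond the usual scatter is also unsettled.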